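A few compounds are considered here, and "the series" means these few. Any claim that something is new, unique, unknown or untested is made for them only; others in the source may bear on it.

Values in a functional assay on MCF7 cells (Homo sapiens) for inhibition, read by fluorescence, with a stated time of 72 h (a lower number here means a stronger inhibitor of growth, a higher number a weaker inhibitor of growth), so far

compound 1 `COc1ccc(Nc2nc(N[C@H]3CC[C@H](N)CC3)nc3c2ncn3CCC(C)C)c(OC)c1` gives 6300 nM
compound 2 `CCCCCCn1cnc2c(Nc3ccc(Cl)cc3)nc(N[C@H]3CC[C@H](N)CC3)nc21` gives 4200 nM
compound 3 `COc1ccc(Cn2cnc3c(Nc4cccc(Cl)c4)nc(N[C@H]4CC[C@H](N)CC4)nc32)cc1` gives 4800 nM

Compound 3 is the middle number of the three, but it lies within the scatter of both neighbours, so the three values cannot be ranked. Among the compounds with values here, no pair of measured compounds differs in only one place, so the series offers no measured single-change step to lean on.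

Next is compound 4 `CC(C)=CCn1cnc2c(Nc3cccc(Cl)c3)nc(N[C@H]3CC[C@H](N)CC3)nc21`, which differs from compound 3 as follows: 2-methylprop-1-en-1-yl in place of 4-methoxyphenyl on a saturated chain carbon bound to an aromatic nitrogen. In words, this is 2-methylprop-1-en-1-yl in place of 4-methoxyphenyl on a saturated chain carbon bound to an aromatic nitrogen. Cut one bond further out, the same difference reads 4-methoxybenzyl to 3-methylbut-2-en-1-yl.

The three measured compounds differ from one another in more than one place, yet their values stay within the scatter of each other. The expectation therefore starts from compound 3 at 4800 nM and assumes the new group leaves that level in place. In this assay the expected step of a 1.1-fold lower number from compound 3 to compound 4 (0.03 log units; within the scatter) is none beyond the scatter, with no direction favoured. For compound 4 the estimated value is 4500 nM, with an expected range from 2000 nM to 10000 nM.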

Compound 4, concentration for 50% growth inhibition: 4200 nM
Compound 4: middle estimate off by 1.1-fold (0.03 log units), on the high side; low and high end bracket the measured number.
By their numbers in this assay, from the lowest: compounds 2, 4, 3 and 1 (each within the scatter of the next).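

Within the data shown here, at the saturated chain carbon bound to an aromatic nitrogen, the series now has its first comparison that differs in one place: in this assay, 2-methylprop-1-en-1-yl in place of 4-methoxyphenyl gives a 1.1-fold lower number from compound 3 to compound 4 (0.06 log units; within the scatter), the only measured single-place step so far. For this pair, the six-membered aromatic ring and the hydrogen-bond acceptor of the leaving group can go, and the smaller, ring-free 2-methylprop-1-en-1-yl can take their place, with no separation beyond the scatter in this read-out. Nothing measured here explains why the two compounds cannot be told apart.

A single pair on a single shared core leaves open whether the same exchange would read alike with the other groups carried by compound 1 or compound 2. Also open is how this position responds to a group ending in a carboxylic acid, a primary amine or a morpholine, since the chain-carbon substituents shown here carry no charge.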